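The source may hold more compounds than are shown below. What is called first, only, known or untested is meant among the compounds shown, and "the series" means these compounds.

Compound 1 `O=C(O)c1cc2cc(O)ccc2oc1=O` gives 40200 nM in an in vitro assay on BTI-TN-5B1-4 cells for inhibition of Amine oxidase [flavin-containing] A (Homo sapiens), read by fluorescence, with a stated time of 15 min; on this read-out lower numbers stand for stronger inhibition and higher numbers for weaker inhibition. Compound 2 `O=C(NNc1ccccc1)c1cc2ccccc2oc1=O` gives 41400 nM in this assay, and compound 3 `O=C(NNc1ccccc1[N+](=O)[O-])c1cc2ccccc2oc1=O` gives 39600 nM in this assay. Compound 3 stands level with the other two: its number lies within the scatter of that of compound 1 and of that of compound 2, so no order among the three can be read from these numbers.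

Compound 4 `O=C(NNc1ccc([N+](=O)[O-])cc1[N+](=O)[O-])c1cc2ccccc2oc1=O` differs from compound 3 by nitro in place of hydrogen on an aromatic carbon. Going by the values given here, one measured step bears directly on this change, the same kind of exchange of a nitro for a hydrogen: a 1.0-fold lower number from compound 2 to compound 3 (0.02 log units; within the scatter). That step stayed within the scatter, so from a second nitro no step beyond the scatter is expected in this assay, in neither direction. Compound 4 is therefore estimated at 39000 nM, with a range from 20000 nM to 80000 nM. The step that this estimate means, a 1.0-fold lower number from compound 3 to compound 4 (0.01 log units; within the scatter), is expected to remain within the scatter.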

Compound 4, half-maximal inhibitory concentration: 60500 nM
Beside the measured number, compound 4's estimate is 1.6-fold (0.19 log units) below it; measured number inside the range.
By their numbers in this assay, from the lowest: compounds 3, 1, 2 and 4 (each within the scatter of the next).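

In this assay, a second nitro, on the aromatic carbon para to a large group and meta to a nitro group, gives a 1.5-fold higher number from compound 3 to compound 4 (0.18 log units; within the scatter). Read with a 1.0-fold lower number from compound 2 to compound 3 (0.02 log units; within the scatter), this shows that the new position also takes a nitro in place of hydrogen with no step beyond the scatter, so the change has now stayed within the scatter at two successive additions. Nothing available here bears on the reason for this result.

On these data alone, whether a different group at this position, such as an amine or a chlorine, would bring a step beyond the scatter remains open. Also open, as far as these compounds go, is whether a change elsewhere on the shared core, such as a methyl or a longer chain, would move the number beyond the scatter.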